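Dichloro to difluoro on the carbonyl-bound ring of compound 2

The source may hold more compounds than are shown below. What is called first, only, known or untested is meant among the compounds shown, and "the series" means these compounds.

Compound 1 `COc1ccc(-c2cc(/C=C/C(=O)c3ccc(N)cc3)[nH]n2)cc1` gives 2570 nM in a functional assay on U-251 cells (Homo sapiens) for inhibition, read by sulforhodamine B assay, with a stated time of 48 h; a lower number here means a stronger inhibitor of growth, a higher number a weaker inhibitor of growth. Compound 2 `COc1cc(-c2cc(/C=C/C(=O)c3ccc(Cl)c(Cl)c3)[nH]n2)cc(OC)c1OC` gives 80500 nM in this assay, the higher of the two numbers; compound 1 stands far lower, beyond the scatter. Compound 3 `COc1cc(-c2cc(/C=C/C(=O)c3ccc(F)c(F)c3)[nH]n2)cc(OC)c1OC` differs from compound 2 by 3,4-difluorophenyl in place of 3,4-dichlorophenyl on a carbonyl carbon. Among the measured compounds shown here, no measured pair shows this change, so its size is unknown from these data; the expectation is a step of no more than the scatter, in no firm direction. Compound 3 is therefore expected to give about 60000 nM in this assay, within a range of 15000 nM to 200000 nM. The expected step is a 1.3-fold lower number from compound 2 to compound 3 (0.13 log units; within the scatter), inside the scatter.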

Compound 3, concentration for total growth inhibition: 15700 nM
For compound 3 the middle estimate is 3.8-fold (0.58 log units) above the measured one; the measured number falls inside the stated range.
By their numbers in this assay, from the lowest: compound 1; then compound 3; then compound 2.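

In this assay, the position on a carbonyl carbon responds to the identity of the halogens: 3,4-difluorophenyl in place of 3,4-dichlorophenyl gives a 5.1-fold lower number from compound 2 to compound 3 (0.71 log units; beyond the scatter). Among the compounds shown here, this is the first step that changes one place only, and the two groups match in heavy-atom count and in hydrogen-bond donors and acceptors. Nothing available accounts for the step.

From the compounds shown here alone, it remains open how an unsubstituted phenyl or a trifluoromethylphenyl would behave at this position. Going by these compounds, whether the step carries over to the core of compound 1 also remains open.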